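A Fluoro to Trifluoromethyl Exchange in Growth Inhibition

A few compounds are considered here, and "the series" means these few. Any claim that something is new, unique, unknown or untested is made for them only; others in the source may bear on it.

In a functional assay on KB cells (Homo sapiens) for inhibition, read by sulforhodamine B assay (on this read-out lower numbers stand for stronger inhibition of growth and higher numbers for weaker inhibition of growth), compound 1 (`Cc1ccc2[nH]c(-c3ccc(-c4ccc(-c5cccc(Cl)c5)cc4)cc3)nc2c1`) gives 2260 nM, while compound 2 (`Cc1ccc2[nH]c(-c3ccc(-c4ccc(-c5ccc(F)cc5)cc4)cc3)nc2c1`) gives 24900 nM, the higher of the two numbers. Among the measured compounds shown here, the only measured step, an 11-fold higher number from compound 1 to compound 2 (1.04 log units; beyond the scatter), is large and beyond the scatter, with 4-fluorophenyl in place of 3-chlorophenyl on an aromatic carbon. Compound 3 (`Cc1ccc2[nH]c(-c3ccc(-c4ccc(-c5ccc(C(F)(F)F)cc5)cc4)cc3)nc2c1`) differs from compound 2 in one place: trifluoromethyl in place of fluoro on an aromatic carbon. This puts trifluoromethyl in place of fluoro on an aromatic carbon, para to a large group. For the measured compounds named here, no measured step covers this exchange, so the step above is only a loose guide, showing that one exchange of this kind can be large. With compound 2 at the high end at 24900 nM, a moderate move to a lower number is expected, estimated as a 2.5-fold lower number from compound 2 to compound 3 (0.40 log units; beyond the scatter). For compound 3 the expected value is 10000 nM, with an estimated range from 2500 nM to 35000 nM.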

Compound 3, concentration for 50% growth inhibition: 41200 nM
Estimate against measurement, compound 3: 4.1-fold (0.61 log units) below; the measured number lies above the stated range.
By their numbers in this assay, from the lowest: compound 1; then compounds 2 and 3 (each within the scatter of the next).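

In this assay, trifluoromethyl in place of fluoro, para to a large group, gives a 1.7-fold higher number from compound 2 to compound 3 (0.22 log units; within the scatter), so at this place the group of four heavy atoms reads no differently from the single fluorine. Both 4-fluorophenyl and 4-(trifluoromethyl)phenyl therefore leave the number well above that of compound 1, and the new step, an 18-fold higher number from compound 1 to compound 3 (1.26 log units; beyond the scatter), is large like the earlier one. No measurement given here bears on the reason for this result.

The compounds shown do not separate the identity of the group from its place on the ring, as the 3-chlorophenyl of compound 1 differs from the other two in both. From the compounds shown here alone, whether an amine, a carboxylic acid or a methoxy group at this place would keep the number in the same range also stays open.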